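The compounds below may be only part of what the source reports. "The series", "measured", "known", "first", "only" and "open" are said of these compounds alone.

Compound 1 `Cc1ccc(C(=O)/C=C/c2ccc3c(c2)B(O)OC3)cc1` is the reference point of the pair measured so far. In a functional assay on SK-OV-3 cells (Homo sapiens) for cytotoxicity, read by MTT assay, with a stated time of 48 h (a higher number here means a weaker inhibitor, a lower number a stronger inhibitor), compound 1 gives 3700 nM, the lowest of the two numbers shown, with compound 2 `CCOC(=O)c1ccc(C(=O)/C=C/c2ccc3c(c2)B(O)OC3)cc1` within the scatter of it at 7100 nM. Among the compounds with values here, the only step in hand, a 1.9-fold higher number from compound 1 to compound 2 (0.28 log units; within the scatter), exchanges one substituent on the aryl ring attached to the carbonyl carbon and stays within the scatter. Compound 3 `Nc1cccc(C(=O)/C=C/c2ccc3c(c2)B(O)OC3)c1` is the next member to be tested: 3-aminophenyl in place of 4-methylphenyl on a carbonyl carbon. Within the data shown here, the one measured step bears on this change only loosely: it too alters the aryl ring on the carbonyl carbon, and that alteration stayed within the scatter. On that basis no step beyond the scatter is expected for compound 3 in this assay, in either direction. The expected result for compound 3 is 4000 nM, with a range of 1500 nM to 11000 nM, which corresponds to an expected step of a 1.1-fold higher number from compound 1 to compound 3 (0.03 log units; within the scatter).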

Compound 3, half-maximal inhibitory concentration: 7400 nM
For compound 3 the middle estimate is 1.9-fold (0.27 log units) below the measured one; low and high end bracket the measured number.
By their numbers in this assay, from the lowest: compounds 1, 2 and 3 (each within the scatter of the next).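

In this assay the exchange of 4-methylphenyl for 3-aminophenyl gives a 2.0-fold higher number from compound 1 to compound 3 (0.30 log units; within the scatter) and adds a second replacement on the carbonyl carbon that stays within the scatter. Unlike the ethoxycarbonyl step, this one brings in 1 hydrogen-bond donor and 1 hydrogen-bond acceptor where 4-methylphenyl has 0 of each, and the number remains within the scatter; none of the three compounds goes against this so far. No measurement available here explains the size of this step.

The exchange alters both the substituent and its place on the aryl ring, so the two contributions cannot be separated. As far as these compounds go, whether a carboxylic acid, a longer alkyl chain or a saturated ring in place of the aryl group on the carbonyl carbon would give a step beyond the scatter remains open.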